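The source may hold more compounds than are shown below. What is called first, only, known or untested is meant among the compounds shown, and "the series" means these compounds.

Compound 2 `Oc1cc(C(F)(F)F)ccc1-c1nc(-c2ccccc2O)n(-c2ccc(Br)cc2)n1` was examined in a functional assay on PC-12 cells (Rattus norvegicus) for cytotoxicity, read by MTT assay, with stated times of 2 h and 24 h, tested at 1 uM (a higher number here means a stronger effect of the compound at the concentration tested, a lower number a weaker effect), and there compound 2 gives 69.4%. Going by the values given here, compound 1 `CC(C)(C)c1ccc(-n2nc(-c3ccc(C(F)(F)F)cc3O)nc2-c2ccccc2O)cc1` is the only other compound measured; in this assay compound 1 gives 67.3%. Compound 2 thus stands highest of the two numbers, but the step of a number 2.1 percentage points higher from compound 1 to compound 2 (within the scatter) lies within the scatter, so the two cannot be ranked. Compound 3 `N#Cc1ccc(-n2nc(-c3ccc(C(F)(F)F)cc3O)nc2-c2ccccc2O)cc1` differs from compound 2 in a single place: cyano in place of bromo on an aromatic carbon. Among the compounds with values here, the one measured step, a number 2.1 percentage points higher from compound 1 to compound 2 (within the scatter), altered the group at this same place and left the read-out essentially where it was, yet no measured step exchanges bromo for cyano, so the weight of that particular change is unknown. On this basis a step of a number 1.4 percentage points lower from compound 2 to compound 3 (within the scatter) is expected in this assay, nothing beyond the scatter. Compound 3 is therefore estimated at 68%, with a range from 55% to 80%.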

Compound 3, a percentage reported as activity, at one concentration (the size of the read-out at that concentration, not a potency): 66.6%
Estimate against measurement, compound 3: 1.4 percentage points above; low and high end bracket the measured number.
By their numbers in this assay, from the lowest: compounds 3, 1 and 2 (each within the scatter of the next).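

In this assay, exchanging bromo for cyano gives a number 2.8 percentage points lower from compound 2 to compound 3 (within the scatter), and exchanging tert-butyl for cyano gives a number 0.7 percentage points lower from compound 1 to compound 3 (within the scatter). Cyano, which brings a triple bond and a hydrogen-bond acceptor that neither of the other two groups has, thus joins tert-butyl and bromo as a third group at this position that the read-out cannot separate from them. No independent evidence on the cause of this outcome is available. From the compounds shown here alone, whether an amine, a carboxylic acid or a longer chain at this position would stay within the scatter of these three compounds remains open. Also open, going by these compounds, is what a change elsewhere on the shared core, such as at the trifluoromethyl group, would do to the read-out.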